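Fluoro for Methoxy Where Every Value Is a Limit

The compounds below may be only part of what the source reports. "The series", "measured", "known", "first", "only" and "open" are said of these compounds alone.

Measured so far in a functional assay on COLO 320 cells (Homo sapiens) for cytotoxicity, read by WST assay, with a stated time of 72 h; a higher number here means a weaker inhibitor, a lower number a stronger inhibitor:
- compound 1 `Cn1c(-c2cc(-c3cccc(F)c3)on2)cc2ccccc21`, for which compound 1 gives > 100000 nM
- compound 2 `COc1cccc(-c2cc(-c3cc4cc(OC)ccc4[nH]3)no2)c1`, for which compound 2 gives > 100000 nM
- compound 3 `Cn1c(-c2cc(-c3ccc(F)cc3)no2)cc2ccccc21`, for which compound 3 gives > 100000 nM

Each of these values is a limit of the assay, not a number. Compound 2 therefore stands at the same limit as the other two, and nothing sets it apart from them; all three sit at the limit of > 100000 nM in this assay, at which 3 of the 3 values shown sit.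

Compound 4 `COc1ccc2[nH]c(-c3cc(-c4cccc(F)c4)on3)cc2c1` is not yet measured. It differs from compound 2 by fluoro in place of methoxy on an aromatic carbon. Among the compounds with values here, no measured pair shows what such a change does here, so no step beyond the scatter is expected in this assay, in either direction. Compound 4 is estimated at 100000 nM, with a range from 30000 nM to 300000 nM, and the step from compound 2 is expected to be a number no higher from compound 2 to compound 4 (the limit leaves the size open), most likely reported again as a limit.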

Compound 4, half-maximal inhibitory concentration: > 100000 nM
Compound 4: a limit, no number (the forecaster's own chance of this, stated with the estimate: 85%); the middle value sits exactly at the limit.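

Within the data shown here, compound 2 and compound 4 are both reported only as limits, not numbers, so no step between them can be read. The compounds shown leave open what fluoro in place of methoxy does in this assay, and where any of the four truly stands: the limit of > 100000 nM in this assay, at which 4 of the 4 values shown sit.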